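A few compounds are considered here, and "the series" means these few. Any claim that something is new, unique, unknown or untested is made for them only; others in the source may bear on it.

Measured so far:
- compound 1 `COc1ccc(NC(=O)c2ccc(OCCCCl)c([N+](=O)[O-])c2)cc1`: 39700 nM
- compound 2 `CCC(=O)Nc1cc(C(=O)Nc2ccc(CN3CCN(C)CC3)c(C(F)(F)F)c2)ccc1OC(C)C`: 15300 nM
- compound 3 `CCC(=O)Nc1cc(C(=O)Nc2ccc(OC)cc2)ccc1OCCCCl`: 158000 nM

In a toxicity assay on Huh-7.5 cells (Homo sapiens) for inhibition, read by MTT assay, with a stated time of 96 h (on this read-out lower numbers stand for higher toxicity in this test and higher numbers for lower toxicity in this test), compound 3 has the highest number of the three at 158000 nM, beyond the scatter from both others. Compound 4 `CCOc1ccc(C(=O)Nc2ccc(OC)cc2)cc1NC(=O)CC` differs from it as follows: hydrogen in place of chloromethyl on a saturated chain carbon, two bonds along the chain from an oxygen on an aromatic ring, which also reads 3-chloropropoxy to ethoxy. Going by the values given here, no measured step covers this change. The only one, a 4.0-fold higher number from compound 1 to compound 3 (0.60 log units; beyond the scatter), is a change elsewhere in the structure, so it bears only loosely and gives no direction here. No shift beyond the scatter is therefore expected in this assay. The expected step is a 1.3-fold lower number from compound 3 to compound 4 (0.12 log units; within the scatter). For compound 4 the estimated value is 120000 nM, with an expected range of 40000 nM to 300000 nM.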

Compound 4, half-maximal cytotoxic concentration: 73200 nM
The estimate for compound 4 lay 1.6-fold (0.21 log units) above the measured number; the measured number falls inside the stated range.
By their numbers in this assay, from the lowest: compound 2; then compounds 1 and 4 (each within the scatter of the next); then compound 3.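

In this assay, shortening 3-chloropropoxy to ethoxy gives a 2.2-fold lower number from compound 3 to compound 4 (0.33 log units; beyond the scatter), the first step read at this chain; the earlier step lay elsewhere, at the nitro position. Loss of chloromethyl here therefore goes with higher toxicity in this test, a modest step but beyond the scatter. No supporting measurement accounts for the shift. The step removes the chlorine and shortens the chain together, and propoxy would part those two changes. Open too, as far as these compounds go, is how an amine in place of chloromethyl would read.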